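The compounds below may be only part of what the source reports. "The series", "measured", "known", "first", "only" and "open" are said of these compounds alone.

Compound 1 `CC(O)(CSc1cccc(S(F)(F)(F)(F)F)c1)C(=O)Nc1ccc(C#N)c(C(F)(F)F)c1` and compound 2 `CC(O)(CSc1cccc(S(F)(F)(F)(F)F)c1)C(=O)Nc1ccc([N+](=O)[O-])c(C(F)(F)F)c1` share one core, and compound 3 `CC(O)(CS(=O)(=O)c1cccc(S(F)(F)(F)(F)F)c1)C(=O)Nc1ccc(C#N)cc1C(F)(F)F` and compound 4 `CC(O)(CS(=O)(=O)c1cccc(S(F)(F)(F)(F)F)c1)C(=O)Nc1ccc([N+](=O)[O-])cc1C(F)(F)F` share another. How the two cores differ is not broken down here. In a functional assay on DU-145 cells (Homo sapiens) for antiproliferative activity, read by propidium iodide staining, with a stated time of 96 h (on this read-out higher numbers stand for weaker inhibition and lower numbers for stronger inhibition), compound 1 gives 32700 nM, while compound 2 gives 13900 nM. Within the data shown here, the single change between them, (nitro in place of cyano on an aromatic carbon), made a step of a 2.4-fold lower number from compound 1 to compound 2 (0.37 log units; beyond the scatter). Compound 3 gives 22100 nM in this assay; the gaps to compound 1 and to compound 2 are both within the scatter, so the three numbers for these compounds cannot be placed in an order.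

The change from compound 3 to compound 4 is nitro in place of cyano on an aromatic carbon. It is the same kind of change as that from compound 1 to compound 2, but not the same: in compound 1 the cyano sits ortho to a trifluoromethyl group, whereas in compound 3 it sits meta to a trifluoromethyl group, in both cases para to a large group. Among the measured compounds shown here, with only one measured example of this kind of change, the expectation for compound 4 rests on compound 1 and compound 2, because a 2.4-fold lower number from compound 1 to compound 2 (0.37 log units; beyond the scatter) is the only guide to its size. It is therefore expected that the step from compound 3 to compound 4 in this assay will be about a 2.3-fold lower number from compound 3 to compound 4 (0.37 log units; beyond the scatter). Compound 4 is estimated to give 9500 nM in this assay, with a likely range from 4000 nM to 25000 nM.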

Compound 4, half-maximal inhibitory concentration: 100000 nM
Estimate against measurement, compound 4: 11-fold (1.02 log units) below; measured number outside the range, above it.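

In this assay, the replacement of cyano by nitro on an aromatic carbon did not carry over from one core to the other: on the second core it gave a 4.5-fold higher number from compound 3 to compound 4 (0.66 log units; beyond the scatter), which runs against the earlier step, and the two steps clearly differ: the same change on two cores in this assay, a 2.4-fold lower number (0.37 log units; beyond the scatter) from compound 1 to compound 2 and a 4.5-fold higher number (0.66 log units; beyond the scatter) from compound 3 to compound 4, 11-fold (1.03 log units) apart, beyond the scatter of two such steps Within this series, then, the step seen on the core of compound 1 was no reliable guide to either the direction or the size of the step on the core of compound 3, and the effect of this change has to be read in the context of each core. Among these compounds, the result does not show which structural difference between the two cores reverses the step, and with only one pair on each core it supports no general rule about either group.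

The compounds shown leave open whether the sulfur link, as thioether or sulfone, or the place of the trifluoromethyl group decides the outcome, since no pair here separates the two. They also leave open how a chlorine atom or an amine on that same aromatic carbon would behave on either core, and whether such groups would show the same dependence on the core.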